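This account rests on a few compounds, and the source may have more. Where it says the series, first, only, none or still open, it means among the compounds named here.

Compound 1 `CCCNC(=O)c1ccc(Oc2nc(-c3c(C)noc3C)cnc2N)cc1` is the starting point. In a functional assay on LoVo cells (Homo sapiens) for inhibition, read by MTT assay, with a stated time of 72 h (a higher number here means a weaker inhibitor, a lower number a stronger inhibitor), compound 1 gives 17500 nM, the higher of the two numbers read in this series. Compound 2 `Cc1noc(C)c1-c1cnc(N)c(Oc2ccc(C(=O)NC3CC3)cc2)n1`, which carries a cyclopropyl on the amide-type nitrogen, is reported only as a limit of the assay, > 100000 nM, and not as a number. Compound 3 `Cc1noc(C)c1-c1cnc(N)c(Oc2ccc(C(=O)Nc3ccccc3)cc2)n1`, with a phenyl in that position, gives 5740 nM. The measured steps are an at least 5.7-fold higher number from compound 1 to compound 2 (0.75 log units; beyond the scatter), a 3.0-fold lower number from compound 1 to compound 3 (0.48 log units; beyond the scatter) and an at least 17-fold lower number from compound 2 to compound 3 (1.24 log units; beyond the scatter); the one that bears most directly on the new compound is the step to compound 3, since it also replaces the propyl with an aromatic ring.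

Compound 4 `Cc1noc(C)c1-c1cnc(N)c(Oc2ccc(C(=O)Nc3cccc(Cl)c3)cc2)n1` differs from compound 1 as follows: 3-chlorophenyl in place of propyl on an amide-type nitrogen. Given that the unsubstituted phenyl already lowered the number in the step of a 3.0-fold lower number from compound 1 to compound 3 (0.48 log units; beyond the scatter), compound 4 is expected to show a step of similar size and direction, a 5.0-fold lower number from compound 1 to compound 4 (0.70 log units; beyond the scatter). Compound 4 is therefore estimated at 3500 nM, within a range from 1000 nM to 12000 nM.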

Compound 4, half-maximal inhibitory concentration: 1640 nM
For compound 4 the middle estimate is 2.1-fold (0.33 log units) above the measured one, within the range that was stated.
By their numbers in this assay, from the lowest: compound 4; then compound 3; then compound 1. At a limit, above all of these: compound 2.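

Chloro in place of hydrogen on the aromatic ring takes the number further down, a 3.5-fold lower number from compound 3 to compound 4 (0.54 log units; beyond the scatter), so the phenyl on the amide-type nitrogen can carry a substituent, and in this assay this one improves on the unsubstituted ring. Measured against the propyl of the starting point, the whole change gives an 11-fold lower number from compound 1 to compound 4 (1.03 log units; beyond the scatter), a large step where the unsubstituted phenyl alone had been a modest one. The step of an at least 60-fold lower number from compound 2 to compound 4 (1.78 log units; beyond the scatter) is a bound only, its starting value being a limit of the assay and not a number: the limit of > 100000 nM in this assay, at which 1 of the 4 values shown sits.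

The compounds shown leave open whether this gain belongs to chloro itself or would also come with a fluoro, a methoxy or a nitrile on the same ring. Also open, from the compounds shown here alone, is whether a 4-chlorophenyl or 2-chlorophenyl would match the 3-chlorophenyl.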